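Aniline-to-pyridylamine swap on the quinazoline series

The source may report more compounds than this note shows. Statements on the series, on what has been measured and on what is new or still open speak of the compounds shown alone.

Measured compounds:
compound 1 `CCS(=O)(=O)Nc1cc(-c2ccc3ncnc(Nc4ccc(OC)cc4)c3c2)cnc1OC` – 3970 nM
compound 2 `COC(=O)c1cccc(Nc2ncnc3ccc(-c4cnc(OC)c(NS(=O)(=O)c5ccc(F)cc5F)c4)cc23)c1` – 400 nM

In a functional assay on SNU-638 cells (Homo sapiens) for cytotoxicity, read by sulforhodamine B assay, with a stated time of 72 h (a higher number here means a weaker inhibitor, a lower number a stronger inhibitor), compound 1 gives 3970 nM, the higher of the two numbers. Compound 2 gives 400 nM, a number beyond the scatter apart from compound 1; compound 2 differs from compound 1 in more than one place, so the two values can only be set side by side, not read as a single step.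

Compound 3 `CCS(=O)(=O)Nc1cc(-c2ccc3ncnc(Nc4ccc(OC)nc4)c3c2)cnc1OC` is not yet measured. It differs from compound 1 in one place: 6-methoxypyridin-3-yl in place of 4-methoxyphenyl on a nitrogen on an aromatic ring, so 6-methoxypyridin-3-yl in place of 4-methoxyphenyl on a nitrogen on an aromatic ring. Within the data shown here, no step between measured compounds bears on this change, so there is no measured precedent in this set.

With nothing else in the series to go on, the step from compound 1 to compound 3 in this assay is expected to be a 1.0-fold higher number from compound 1 to compound 3 (0.00 log units; within the scatter), that is, none beyond the scatter. Compound 3 is accordingly estimated at 4000 nM, with a range from 1500 nM to 11000 nM.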

Compound 3, half-maximal inhibitory concentration: 4280 nM
Compound 3: the middle estimate sits 1.1-fold (0.03 log units) below what was measured, and the stated range covers the measured number.
By their numbers in this assay, from the lowest: compound 2; then compounds 1 and 3 (each within the scatter of the next).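

In this assay, the series now has its first step that differs in one place: 6-methoxypyridin-3-yl in place of 4-methoxyphenyl on a nitrogen on an aromatic ring gives a 1.1-fold higher number from compound 1 to compound 3 (0.03 log units; within the scatter). At this position, therefore, a carbon of the six-membered aromatic ring can be exchanged for a nitrogen, with the heavy-atom count staying at 8 and the hydrogen-bond acceptors counted in the group going from 1 to 2, while the cytotoxicity readings of the two compounds remain within the scatter of each other. No measurement in hand accounts for this result.

Going by these compounds, it remains open whether an amine, a carboxylic acid or a longer chain in place of the methoxy group on the 6-methoxypyridin-3-yl ring would give a step beyond the scatter. Also open, on these data alone, is whether the same exchange would read alike on a background such as compound 2, which differs from compound 1 in more than one place and so offers no single-step comparison here.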